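Swapping furan for imidazole on an aryloxymethyl-imidazoline scaffold

The source may hold more compounds than are shown below. What is called first, only, known or untested is meant among the compounds shown, and "the series" means these compounds.

Measured compounds:
compound 1, `Cc1ccnc(-c2ccccc2OCC2=NCCN2)c1`, < 100000 nM
compound 2, `c1coc(-c2ccccc2OCC2=NCCN2)c1`, 10 nM

Of the compounds shown here, two sharing the same core have been measured in a functional assay for activation of Alpha-1B adrenergic receptor (Homo sapiens), read by calcium flux; a lower number here means that less compound is needed, a higher number that more compound is needed for the effect. Compound 1, `Cc1ccnc(-c2ccccc2OCC2=NCCN2)c1`, gives only a limit in this assay, < 100000 nM, which is not a number. Compound 1 thus contributes only this: the limit of < 100000 nM in this assay, at which 1 of the 2 values shown sits. Compound 2, `c1coc(-c2ccccc2OCC2=NCCN2)c1`, is the one compound with a real value here and reaches 10 nM; it therefore stands as the only number shown.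

Compound 3, `c1ccc(-c2ncc[nH]2)c(OCC2=NCCN2)c1`, has not yet been measured. It differs from compound 2 by a single exchange: 1H-imidazol-2-yl in place of furan-2-yl on an aromatic carbon. Among the measured compounds shown here, no step between two measured compounds with this kind of change is available, so the size of the step cannot be read off from the data.

An exchange of one five-membered aromatic ring for another, with a hydrogen-bond donor now entering, is expected here to cost some potency, but the outcome is uncertain and the step from compound 2 to compound 3 in this assay is estimated at an 8.0-fold higher number from compound 2 to compound 3 (0.90 log units; beyond the scatter). Compound 3 is expected to give about 80 nM in this assay, within a range from 8 nM to 800 nM.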

Compound 3, half-maximal effective concentration: < 100000 nM
Compound 3 was reported as a limit; the forecaster's own chance of this, stated with the estimate: 10%; the middle value is on the limit's open side.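

In this assay, among the compounds shown here, compound 3 gives < 100000 nM, which is a limit of the assay and not a number, so no step from compound 2 to compound 3 can be read. The compounds shown leave open how much the exchange of furan-2-yl for 1H-imidazol-2-yl changes the value, and whether compound 3 has any measurable value in this assay.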